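Swapping the Acetyl Group for a Tetrazole Ring

The source may report more compounds than this note shows. Statements on the series, on what has been measured and on what is new or still open speak of the compounds shown alone.

Compound 1 `CC(=O)CCSC(=S)NCc1cccnc1` carries an acetyl group on the chain beyond the sulfur of the shared core. In a functional assay on Bel-7402 cells (Homo sapiens) for cytotoxicity, read by resazurin assay, with a stated time of 72 h (on this read-out higher numbers stand for weaker inhibition and lower numbers for stronger inhibition), compound 1 gives 3430 nM. That is the lowest of the two numbers recorded here, and the nearest of them belongs to compound 2 `CCCCOC(=O)CCSC(=S)NCc1cccnc1`, which in this assay gives 6350 nM; the step of a 1.9-fold higher number from compound 1 to compound 2 (0.27 log units; within the scatter) is within the scatter, so the ketone and the butyl ester cannot be told apart on this read-out. Compound 3 `O=C(CCSC(=S)NCc1cccnc1)NCc1ccccc1` returns only a limit in this assay, namely > 100000 nM. That third entry sits at the limit of > 100000 nM in this assay, at which 1 of the 3 values shown sits, and is not a number.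

Compound 4 `S=C(NCc1cccnc1)SCCc1nnn[nH]1` differs from compound 1 in one place: 1H-tetrazol-5-yl in place of acetyl on a saturated chain carbon, two bonds along the chain from a sulfur. Within the data shown here, no measured step covers such a ring in that place. Among the measured compounds shown here, the only measured step, a 1.9-fold higher number from compound 1 to compound 2 (0.27 log units; within the scatter), was flat, while compound 3 with its amide gave only a limit; both replace the acetyl group with another carbonyl-bearing group, so they bear on the tetrazole change only loosely. The account therefore expects a 3.5-fold higher number from compound 1 to compound 4 (0.54 log units; beyond the scatter), a shift toward a higher number, with wide uncertainty. For compound 4 the estimate in this assay is 12000 nM, expected to lie between 3000 nM and 80000 nM.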

Compound 4, half-maximal inhibitory concentration: 57700 nM
Compound 4: middle estimate off by 4.8-fold (0.68 log units), on the low side; measured number inside the range.
By their numbers in this assay, from the lowest: compounds 1 and 2 (each within the scatter of the next); then compound 4. At a limit, above all of these: compound 3.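

In this assay, 1H-tetrazol-5-yl in place of acetyl on this saturated chain carbon brings a 17-fold higher number from compound 1 to compound 4 (1.23 log units; beyond the scatter), so the number at this position does respond to the group placed there, which the flat step a 1.9-fold higher number from compound 1 to compound 2 (0.27 log units; within the scatter) had not shown. The rise is therefore not confined to the amide of compound 3, the one earlier entry that stood apart, since a group with no carbonyl at all now also moves the number well beyond the scatter, though compound 4 still gives a measured value. Compound 3 remains a limit and not a number, and steps to it cannot be read: the limit of > 100000 nM in this assay, at which 1 of the 4 values shown sits.

The compounds shown leave open whether a carboxylic acid or an amine on the same chain carbon would follow the 1H-tetrazol-5-yl compound or stay with compound 1, and whether a methyl group on the tetrazole ring would alter the result. They also do not tell whether a longer chain carrying the same ring would give a number closer to that of compound 1.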